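Trimethoxyphenyl for chlorophenyl on a shared core

The source may hold more compounds than are shown below. What is called first, only, known or untested is meant among the compounds shown, and "the series" means these compounds.

Measured compounds in an assay on isolated protein for inhibition of Dihydrofolate reductase (Homo sapiens), read by spectrophotometry; a higher number here means a weaker inhibitor, a lower number a stronger inhibitor:
compound 1 `CN(Cc1nc2cc(C(F)(F)F)ccc2nc1-c1ccccc1)c1ccc(Cl)cc1`, 5000 nM;
compound 2 `Cc1ccc(N(C)Cc2nc3cc(C(F)(F)F)ccc3nc2-c2ccccc2)cc1`, 11000 nM;
compound 3 `C#CCN(Cc1nc2cc(C(F)(F)F)ccc2nc1-c1ccccc1)c1ccc(Cl)cc1`, 4000 nM.

Compound 3 sits at the lowest of the three numbers, yet its gap to compound 1 is within the scatter; only compound 2 lies beyond it, with a 2.2-fold higher number from compound 1 to compound 2 (0.34 log units; beyond the scatter) separating those two. The propargyl step a 1.3-fold lower number from compound 1 to compound 3 (0.10 log units; within the scatter) changed little.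

Compound 4 `C#CCN(Cc1nc2cc(C(F)(F)F)ccc2nc1-c1ccccc1)c1cc(OC)c(OC)c(OC)c1` differs from compound 3 by 3,4,5-trimethoxyphenyl in place of 4-chlorophenyl on an amine nitrogen. For the measured compounds named here, no measured step touches this ring's replacement; the nearest guidance is that a change on the same ring, from compound 1 to compound 2, moved the number modestly. A similarly modest shift is therefore expected, direction uncertain, so compound 4 is estimated at 2500 nM, within 600 nM to 10000 nM, a step of a 1.6-fold lower number from compound 3 to compound 4 (0.20 log units; within the scatter).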

Compound 4, inhibition constant: 4000 nM
Compound 4: middle estimate off by 1.6-fold (0.20 log units), on the low side; the measured number falls inside the stated range.
By their numbers in this assay, from the lowest: compounds 3, 4 and 1 (each within the scatter of the next); then compound 2.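

In this assay, placing 3,4,5-trimethoxyphenyl in place of 4-chlorophenyl on the amine nitrogen gave no change at the digits printed from compound 3 to compound 4 (within the scatter) even though the group went from 7 to 12 heavy atoms and from 0 to 3 hydrogen-bond acceptors. The earlier compounds had shown only a single substituent exchange on this ring, whereas here the whole substituted ring was exchanged and the result stayed within the scatter. No measurement shown gives a reason for this result. Still open, as far as these compounds go, is whether a ring carrying a carboxylic acid or an amine would leave the number equally unmoved, and whether the trimethoxyphenyl ring would behave the same with the methyl on the nitrogen in place of propargyl.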